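The source may report more compounds than this note shows. Statements on the series, on what has been measured and on what is new or still open speak of the compounds shown alone.

Compound 1 `CC1(C)c2[nH]nc(NC(=O)c3ccccc3)c2CN1Cc1cccc(C#N)c1`: 980 nM in an assay on Sf21 cells for inhibition of high affinity nerve growth factor receptor (Homo sapiens), read by HTRF, with a stated time of 30 min, in the presence of a further agent that is not named here; a lower number here means a stronger inhibitor, a higher number a weaker inhibitor.
Compound 2 `CC1(C)c2[nH]nc(NC(=O)c3ccccc3)c2CN1Cc1ccc(F)c(F)c1`: 680 nM.

Compound 2 sits at a number that is not separable from that of compound 1: a 1.4-fold lower number from compound 1 to compound 2 (0.16 log units; within the scatter), within the scatter. Compound 3 `CC1(C)c2[nH]nc(NC(=O)c3ccccc3)c2CN1Cc1cc(F)c(F)c(F)c1` differs from compound 2 by fluoro in place of hydrogen on an aromatic carbon, the new fluoro standing ortho to a fluoro group and meta to a fluoro group. Within the data shown here, the only measured step exchanged one ring substituent for two and stayed within the scatter; no measured step adds a single fluoro, so it bears only loosely here. For compound 3 a step of a 1.2-fold lower number from compound 2 to compound 3 (0.08 log units; within the scatter) in this assay is expected, nothing beyond the scatter. Compound 3 is estimated at 560 nM, with a range of 250 nM to 1300 nM.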

Compound 3, half-maximal inhibitory concentration: 6960 nM
Compound 3: middle estimate off by 12-fold (1.09 log units), on the low side; the measured number lies above the stated range.
By their numbers in this assay, from the lowest: compounds 2 and 1 (each within the scatter of the next); then compound 3.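

Adding one fluoro, going from 3,4-difluorophenyl to 3,4,5-trifluorophenyl, is not a neutral change: it gives a 10-fold higher number from compound 2 to compound 3 (1.01 log units; beyond the scatter). Replacing 3-cyanophenyl with 3,4,5-trifluorophenyl also gives a clear shift, a 7.1-fold higher number from compound 1 to compound 3 (0.85 log units; beyond the scatter), so this ring tolerates some substitution patterns far better than others. Nothing available here explains the weakening. Still open, as far as these compounds go, is whether the loss is specific to fluoro or would follow any group in that place. A chloro, methoxy or hydroxyl group on the same aromatic carbon would separate these possibilities.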